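The compounds below may be only part of what the source reports. "The series", "measured", "known", "first", "only" and "open" are said of these compounds alone.

Compound 1 `N#CC1=C(/N=C/Nc2ccc([N+](=O)[O-])cc2)N(c2ccccc2)C(=O)N2CCCCC(N3CCCC3)C12`: 85.6%
Compound 2 `N#CC1=C(/N=C/c2ccccc2)N(c2ccccc2)C(=O)N2CCCCC(N3CCCC3)C12`: 84%

In a functional assay on the whole organism (strain albino) for inhibition, with Rattus norvegicus as the target, read by paw edema, with stated times of 1 h and 3 h, at a dose of 20 mmol/kg by the intraperitoneal route (on this read-out higher numbers stand for a stronger effect at the one dose given and lower numbers for a weaker effect), compound 1 gives 85.6%, and compound 2 gives 84%. Going by the values given here, the only step measured so far is a number 1.6 percentage points lower from compound 1 to compound 2 (within the scatter), which came with phenyl in place of (4-nitrophenyl)amino on a carbon with a double bond to nitrogen. Because a number 1.6 percentage points lower from compound 1 to compound 2 (within the scatter) lies within the scatter, compound 2 stands level with compound 1 rather than beneath it; the two numbers cannot be told apart.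

Compound 3 `COC(=O)C(=O)NC1=C(C#N)C2C(N3CCCC3)CCCCN2C(=O)N1c1ccccc1` is not yet measured. Compared with compound 2 it carries a group of 7 heavy atoms (3 carbon, 1 nitrogen, 3 oxygen; no ring) in place of a group of 8 heavy atoms (7 carbon, 1 nitrogen; one six-membered aromatic ring of carbon only), on a double-bonded ring carbon. Among the compounds with values here, the one step on record touched the same spot of the shared core, yet neither of the two groups that change here appears in it, and the group that enters brings a hydrogen-bond donor and three acceptors where none of the kind stood before. Within the data shown here, no measured step therefore speaks directly to this change; the only evidence available says that swapping the group at this carbon left the read-out essentially unchanged.

On that basis the expected step is a number 4 percentage points lower from compound 2 to compound 3 (within the scatter), and compound 3 is estimated at 80%, within a range from 62% to 92%.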

Compound 3, a percentage reported as inhibition, in the whole organism at one dose (the size of the read-out at that dose, not a potency): 88.3%
The estimate for compound 3 lay 8.3 percentage points below the measured number; measured number inside the range.
By their numbers in this assay, from the lowest: compounds 2, 1 and 3 (each within the scatter of the next).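

At the double-bonded ring carbon, the group need not contain an aromatic ring in order to give a high reading in this assay: ((methoxycarbonyl)carbonyl)amino, which has no ring, replaces the ring-bearing groups of the two earlier compounds. The comparison with the phenyl compound gives (a number 4.3 percentage points higher from compound 2 to compound 3 (within the scatter)) and the comparison with the (4-nitrophenyl)amino compound gives (a number 2.7 percentage points higher from compound 1 to compound 3 (within the scatter)), so this position has now taken three quite different groups, with numbers that cannot be told apart at this single dose. Nothing available explains why such different groups give readings this close.

The compounds shown leave open whether any group on this carbon is needed at all, which a plain amino group or a lone hydrogen there would test, and whether the methyl ester end of the new group matters, which a carboxylic acid or a longer chain in its place would test. They also leave open whether these compounds would still stand level at lower doses, since one dose gives the size of the effect and not a potency.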